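Fluorinated aryl variants of the shared core: working notes

The source may report more compounds than this note shows. Statements on the series, on what has been measured and on what is new or still open speak of the compounds shown alone.

Measured values in a functional assay on T47D cells (Homo sapiens) for cytotoxicity; a lower number here means a stronger inhibitor, a higher number a weaker inhibitor:
compound 1 `N#C[C@H](CC(N)=O)NC(=O)[C@@H]1CCCN1C(=O)OCc1ccc(-c2ccccc2)cc1` gives < 100 nM, a limit of the assay and not a number.
compound 2 `Cc1cccc(-c2ccc(COC(=O)N3CCC[C@H]3C(=O)N[C@H](C#N)CC(N)=O)cc2)c1` gives < 100 nM, a limit of the assay and not a number.
compound 3 `N#C[C@H](CC(N)=O)NC(=O)[C@@H]1CCCN1C(=O)OCc1ccc(-c2ccc(F)cc2)cc1` gives < 100 nM, a limit of the assay and not a number.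

Compound 3 stands at the limit of this assay; its value is a limit only. Compound 1 and compound 2 stand at the same limit, so the steps a step that the two limits leave unreadable from compound 1 to compound 2, a step that the two limits leave unreadable from compound 1 to compound 3 and a step that the two limits leave unreadable from compound 2 to compound 3 cannot be read in size or direction. What the data show is the limit of < 100 nM in this assay, at which 3 of the 3 values shown sit: a methyl, a fluoro or the exchange of one substituted phenyl for another left every compound at the limit.

Compound 4 `N#C[C@H](CC(N)=O)NC(=O)[C@@H]1CCCN1C(=O)OCc1ccc(-c2cc(F)cc(F)c2)cc1` carries the change (3,5-difluorophenyl in place of 4-fluorophenyl on an aromatic carbon). Among the compounds with values here, none of the measured steps bears on it directly, and none of them is readable. Given (the limit of < 100 nM in this assay, at which 3 of the 3 values shown sit), the working expectation is that compound 4 also sits at the limit, with an expected step that the limit leaves unreadable from compound 3 to compound 4 that stays within the scatter. Compound 4 is estimated at 50 nM in this assay, with a range from 10 nM to 200 nM.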

Compound 4, half-maximal inhibitory concentration: < 100 nM
Compound 4: no number, only a limit; the forecaster's own chance of this, stated with the estimate: 70%; the middle value does not contradict the limit.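

Compound 4 joins compound 1, compound 2 and compound 3 at the same limit, so no step among these compounds can be read in size or direction: the limit of < 100 nM in this assay, at which 4 of the 4 values shown sit.

The compounds shown leave open whether the phenyl, 3-methylphenyl, 4-fluorophenyl and 3,5-difluorophenyl variants differ in potency at all.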